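Swapping bromo for trifluoromethyl on compound 2

The source may hold more compounds than are shown below. What is called first, only, known or untested is meant among the compounds shown, and "the series" means these compounds.

Measured so far in an ADME assay on the whole organism with Oryza sativa as the target, tested at 1 uM; a higher number here means a weaker effect of the compound at the concentration tested, a lower number a stronger effect:
compound 1, `C[C@@H](NC(=O)Nc1cccc(C(F)(F)F)c1)c1ccccc1`: 72%
compound 2, `C[C@H](NC(=O)Nc1cccc(C(F)(F)F)c1)c1ccccc1`: 93%
compound 3, `C[C@@H](NC(=O)Nc1ccccc1Br)c1ccccc1`: 100%

Compound 2 holds the second highest of the three numbers in this assay. Its nearest neighbour is compound 3, whose value sits within the scatter of that of compound 2, so the two cannot be told apart. Compound 1 lies furthest away: a number 21 percentage points higher from compound 1 to compound 2 (beyond the scatter). That step rests on (the fact that compounds 1 and 2 differ only in the configuration as drawn); the two compounds share every atom and bond and differ only in configuration as drawn.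

The compound now in question is compound 4, `C[C@H](NC(=O)Nc1cccc(Br)c1)c1ccccc1`. It differs from compound 2 in one place: bromo in place of trifluoromethyl on an aromatic carbon. Among the measured compounds shown here, no measured step covers this change. For the measured compounds named here, the single step on record, from compound 1 to compound 2, alters configuration and leaves every group in place, so it says nothing about bromo replacing trifluoromethyl. Compound 3 carries a bromo group on its ring, yet it differs from compound 2 in two places, and its value and that of compound 2 merely sit within the scatter of each other.

With nothing to point in either direction, compound 4 is expected to give 92%, within 76% to 100%. The expected step is therefore a number 1 percentage points lower from compound 2 to compound 4 (within the scatter), not beyond the scatter.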

Compound 4, a percentage reported as activity, at one concentration (the size of the read-out at that concentration, not a potency): 100%
Estimate against measurement, compound 4: 8 percentage points below, and the stated range covers the measured number.
By their numbers in this assay, from the lowest: compound 1; then compounds 2, 3 and 4 (each within the scatter of the next).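

In this assay, among the compounds shown here, this is the first reading of a swap of groups at this aromatic carbon, meta to a large group, and it comes out as a number 7 percentage points higher from compound 2 to compound 4 (within the scatter). With the configuration drawn in compound 2 held fixed, a single bromine atom can thus stand where the four heavy atoms of trifluoromethyl stood, and compound 2 and compound 4 cannot be told apart by their numbers. Such a result says only that this exchange leaves no readable mark in this setting, and nothing on record bears on the exchange of these two groups.

On these data alone, it remains open whether the same exchange would also go unseen with the opposite configuration, where compound 1, at 72%, carries trifluoromethyl and stands apart from the others, since a stronger effect there would leave more room for a step to show. As far as these compounds go, it is equally open whether a different group at this aromatic carbon, such as a nitrile, a methoxy group or an amine, would move the number beyond the scatter.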